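A few compounds are considered here, and "the series" means these few. Any claim that something is new, unique, unknown or untested is made for them only; others in the source may bear on it.

Measured compounds, with their values in an assay on CHO cells for displacement of a labelled ligand from adenosine receptor A1 (Homo sapiens); on this read-out higher numbers stand for weaker inhibition and lower numbers for stronger inhibition:
- compound 1, `COc1ccc(-c2c(C#N)c(N)nc(SCc3csc(-c4ccc(Br)cn4)n3)c2C#N)cc1`: 53 nM
- compound 2, `COc1ccc(-c2c(C#N)c(N)nc(SCc3cscn3)c2C#N)cc1`: 1.3 nM

Compound 2 has the lowest number of the two measured in this assay; its nearest neighbour is compound 1, and the two are separated by a step beyond the scatter.

The unmeasured compound 3, `COc1ccc(-c2c(C#N)c(N)nc(SCc3csc(-c4ccc(Cl)cc4)n3)c2C#N)cc1`, differs from compound 2 in one place: 4-chlorophenyl in place of hydrogen on an aromatic carbon. Within the data shown here, the only measured step that bears on this change is the one between the same two ring positions, a 41-fold lower number from compound 1 to compound 2 (1.61 log units; beyond the scatter), in which removing the 5-bromopyridin-2-yl substituent from that carbon gave a large drop in the number. Compound 3 reverses the direction of that step, putting an aromatic ring back onto the same carbon, though the ring that enters is 4-chlorophenyl rather than 5-bromopyridin-2-yl. Nothing measured here tells how far the two rings differ from each other in their effect, so the expectation rests on the size of that single step. Compound 3 is therefore expected to show a large rise in the number relative to compound 2, an estimated step of a 27-fold higher number from compound 2 to compound 3 (1.43 log units; beyond the scatter). The estimate for compound 3 in this assay is 35 nM, with a range from 8 nM to 150 nM.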

Compound 3, inhibition constant: 5 nM
The estimate for compound 3 lay 7.0-fold (0.85 log units) above the measured number; measured number outside the range, below it.
By their numbers in this assay, from the lowest: compound 2; then compound 3; then compound 1.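

In this assay, the aromatic carbon next to the ring nitrogen and next to the ring sulfur carries 4-chlorophenyl with only a 3.8-fold higher number from compound 2 to compound 3 (0.59 log units; beyond the scatter) as the cost, so placing an aromatic ring on this carbon does not in itself bring a large rise in the number. The identity of the ring matters more than the earlier pair could show: 4-chlorophenyl in place of 5-bromopyridin-2-yl gives an 11-fold lower number from compound 1 to compound 3 (1.03 log units; beyond the scatter), which accounts for most of the distance between compound 1 and compound 2, while hydrogen in compound 2 still gives the lowest number of the three. No measurement given here explains why the two rings differ in this way.

The exchange between compound 1 and compound 3 alters the ring nitrogen and the halogen together, so the compounds shown cannot say which of the two carries the difference, and an unsubstituted phenyl or a pyridin-2-yl on this carbon would separate them. As far as these compounds go, it also remains open how this carbon responds to something other than an aromatic ring, such as a methyl, an amine or a carboxylic acid.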